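A Repeated Aryl Swap and a Forecast for Compound 4

A few compounds are considered here, and "the series" means these few. Any claim that something is new, unique, unknown or untested is made for them only; others in the source may bear on it.

Compound 1 `COc1ccc(Nc2nc3ccccc3nc2S(=O)(=O)c2ccccc2)cc1`: in a functional assay on A549 cells (Homo sapiens) for cytotoxicity, read by MTT assay, with a stated time of 72 h (on this read-out lower numbers stand for stronger inhibition and higher numbers for weaker inhibition), compound 1 gives 11900 nM.
Compound 2 `COc1cc(Nc2nc3ccccc3nc2S(=O)(=O)c2ccccc2)cc(OC)c1`: in this assay compound 2 gives 70 nM.
Compound 3 `COc1ccc(Nc2nc3ccccc3nc2S(=O)(=O)c2ccc(OC)cc2)cc1`: in this assay compound 3 gives 8260 nM.

Compound 4 `COc1ccc(S(=O)(=O)c2nc3ccccc3nc2Nc2cc(OC)cc(OC)c2)cc1` has not been measured. It differs from compound 3 by 3,5-dimethoxyphenyl in place of 4-methoxyphenyl on a nitrogen on an aromatic ring, and the same change separates compound 1 from compound 2, (3,5-dimethoxyphenyl in place of 4-methoxyphenyl on a nitrogen on an aromatic ring), where it gave a 170-fold lower number from compound 1 to compound 2 (2.23 log units; beyond the scatter). The cores of compound 1 and compound 3 differ by methoxy in place of hydrogen on an aromatic carbon, which gave a 1.4-fold lower number from compound 1 to compound 3 (0.16 log units; within the scatter). Because compound 3 stands at 8260 nM, close to compound 1, a step of similar size is expected again. Beside the measured 170-fold lower number from compound 1 to compound 2 (2.23 log units; beyond the scatter), the expected step is a 140-fold lower number from compound 3 to compound 4 (2.14 log units; beyond the scatter). Compound 4 is therefore estimated at 60 nM, with a likely range from 20 nM to 250 nM.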

Compound 4, half-maximal inhibitory concentration: 12700 nM
Compound 4: the middle estimate sits 210-fold (2.33 log units) below what was measured, outside the stated range (above it).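

The change to 3,5-dimethoxyphenyl did not carry from one core to the other in this assay, where it gave a 1.5-fold higher number from compound 3 to compound 4 (0.19 log units; within the scatter), and the two cores clearly part on this step: the same change on two cores in this assay, a 170-fold lower number (2.23 log units; beyond the scatter) from compound 1 to compound 2 and a 1.5-fold higher number (0.19 log units; within the scatter) from compound 3 to compound 4, 260-fold (2.42 log units) apart, beyond the scatter of two such steps

Read the other way, methoxy in place of hydrogen on an aromatic carbon gave a 180-fold higher number from compound 2 to compound 4 (2.26 log units; beyond the scatter), so its outcome too depends on the core: the same change on two cores in this assay, a 1.4-fold lower number (0.16 log units; within the scatter) from compound 1 to compound 3 and a 180-fold higher number (2.26 log units; beyond the scatter) from compound 2 to compound 4, 260-fold (2.42 log units) apart, beyond the scatter of two such steps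

Among these four compounds the two changes therefore do not act independently, but the data do not show why, nor how either change would behave on any further core.

Still open, as far as these compounds go, is whether a fluorine, an amine or a carboxylic acid in place of that added methoxy would cancel the step in the same way.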